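Fluorophenyl Ester to Naphthyl Ester: Cytotoxicity Outlook

The compounds below may be only part of what the source reports. "The series", "measured", "known", "first", "only" and "open" are said of these compounds alone.

Measured compounds:
compound 1, `CC(C)C(=O)OC1CCC(CN2CCN(c3cc(=O)c4cc(C(F)(F)F)cc([N+](=O)[O-])c4s3)CC2)CC1`, in an ADME assay on Vero cells (Chlorocebus sabaeus) for cytotoxicity, read by MTT assay, with a stated time of 48 h (a higher number here means a weaker inhibitor, a lower number a stronger inhibitor), gives a limit of the assay, > 64 ug/mL.
compound 2, `O=C(OC1CCC(CN2CCN(c3cc(=O)c4cc(C(F)(F)F)cc([N+](=O)[O-])c4s3)CC2)CC1)c1cccc(F)c1`, in this assay gives a limit of the assay, > 64 ug/mL.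

Compound 2 thus stands at the assay's limit, as does compound 1, so the step that the two limits leave unreadable from compound 1 to compound 2 cannot be sized. Compound 3 is `O=C(OC1CCC(CN2CCN(c3cc(=O)c4cc(C(F)(F)F)cc([N+](=O)[O-])c4s3)CC2)CC1)c1ccc2ccccc2c1`, differing from compound 2 by naphthalen-2-yl in place of 3-fluorophenyl on a carbonyl carbon. Going by the values given here, the one measured step concerns the same carbonyl carbon yet gives no readable size, because both values sit at the limit of > 64 ug/mL in this assay, at which 2 of the 2 values shown sit. No shift beyond the scatter is expected, so compound 3 is estimated at 80 ug/mL, between 40 ug/mL and 160 ug/mL, a step that the limit leaves unreadable from compound 2 to compound 3.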

Compound 3, half-maximal inhibitory concentration: > 64 ug/mL
Compound 3 gave a limit, no number (the forecaster's own chance of this, stated with the estimate: 80%); the middle value is on the limit's open side.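

No step among compound 1, compound 2 and compound 3 can be read, because all three give only a limit of the assay and no number: the limit of > 64 ug/mL in this assay, at which 3 of the 3 values shown sit.

The compounds shown leave open whether any group on this carbonyl carbon shifts the result in this assay at all.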